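This account rests on a few compounds, and the source may have more. Where it says the series, first, only, none or still open, it means among the compounds named here.

Compound 1 `COc1cc(N2C(N)=C(C#N)C(c3ccc(OC)c4ccccc34)C3=C2CC(C)(C)CC3=O)cc(OC)c1OC`: 30%
Compound 2 `COc1cc(N2C(N)=C(C#N)C(c3c(O)ccc4ccccc34)C3=C2CC(C)(C)CC3=O)cc(OC)c1OC`: 10%
Compound 3 `COc1cc(N2C(N)=C(C#N)C(c3cccc([N+](=O)[O-])c3)C3=C2CC(C)(C)CC3=O)cc(OC)c1OC`: 20%

All three were run in a functional assay on Ehrlich cells (Mus musculus) for cytotoxicity, tested at 25 ug/mL; a lower number here means a weaker effect, a higher number a stronger effect of the compound at the concentration tested. Compound 3 stands second highest of the three numbers; its gap to compound 1, a number 10 percentage points lower from compound 1 to compound 3 (within the scatter), is within the scatter, as is its gap to compound 2, a number 10 percentage points higher from compound 2 to compound 3 (within the scatter). Only a number 20 percentage points lower from compound 1 to compound 2 (beyond the scatter) goes beyond the scatter. Compound 4 `COc1cc(N2C(N)=C(C#N)C(c3cccs3)C3=C2CC(C)(C)CC3=O)cc(OC)c1OC` is not yet measured. It differs from compound 3 as follows: thiophen-2-yl in place of 3-nitrophenyl on a saturated ring carbon. Every measured step in this set likewise exchanges the group on that saturated ring carbon; two stayed within the scatter and one gave a modest drop. Going by the values given here, no step introduces thiophen-2-yl, so the narrow spread among compounds 1, 2 and 3 is the only guide. For compound 4 a step of no change at the digits printed from compound 3 to compound 4 (within the scatter) is therefore expected, none beyond the scatter. The estimate for compound 4 is 20%, from 5% to 40%.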

Compound 4, a percentage reported as activity, at one concentration (the size of the read-out at that concentration, not a potency): 10%
For compound 4 the middle estimate is 10 percentage points above the measured one, within the range that was stated.
By their numbers in this assay, from the lowest: compounds 2, 4, 3 and 1 (each within the scatter of the next, the first and the last beyond it).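

In this assay the exchange to thiophen-2-yl gives a number 10 percentage points lower from compound 3 to compound 4 (within the scatter) and no change at the digits printed from compound 2 to compound 4 (within the scatter) and so does not separate this five-membered aromatic ring from 3-nitrophenyl or 2-hydroxynaphthalen-1-yl. Against 4-methoxynaphthalen-1-yl it gives a number 20 percentage points lower from compound 1 to compound 4 (beyond the scatter) and so makes a second step of this kind from compound 1, while compound 3 goes against a clean split, lying within the scatter of all the others. Nothing available explains these steps.

Open, going by these compounds, is whether a non-aromatic group such as cyclohexyl at this saturated ring carbon stays in the same narrow band. The same holds for a phenyl bearing an amine or a carboxylic acid.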